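The source may hold more compounds than are shown below. What is called first, only, known or untested is meant among the compounds shown, and "the series" means these compounds.

Compound 2 `COc1ccc(/C=N/NC(=O)COc2cccc3ccccc23)cc1OC` carries two methoxy groups on the shared core. In an ADME assay on HEL cells (Homo sapiens) for cytotoxicity (a higher number here means that more compound is tolerated, a lower number that less compound is tolerated), compound 2 gives >= 20 ug/mL, which is a limit of the assay rather than a number. Its nearest measured relative is compound 1 `COc1cc(/C=N/NC(=O)COc2cccc3ccccc23)cc(OC)c1OC`. In this assay compound 1 gives >= 20 ug/mL, again only a limit. The step that the two limits leave unreadable from compound 1 to compound 2 cannot be sized because of the limit of >= 20 ug/mL in this assay, at which 2 of the 2 values shown sit. Compound 3 `COc1ccc(/C=N/NC(=O)COc2cccc3ccccc23)cc1` is not yet measured and differs from compound 2 by hydrogen in place of methoxy on an aromatic carbon. With no readable step to lean on, compound 3 is expected to remain close to that limit. Compound 3 is estimated at 30 ug/mL with a range from 15 ug/mL to 80 ug/mL and a step that the limit leaves unreadable from compound 2 to compound 3 from the known limit.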

Compound 3, minimum cytotoxic concentration: 20 ug/mL
Compound 3: middle estimate off by 1.5-fold (0.18 log units), on the high side, within the range that was stated.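

In this assay, among the compounds shown here, compound 3 gives 20 ug/mL, the only plain number among the three compounds. Compound 2 gives >= 20 ug/mL, which is a limit. Hydrogen in place of methoxy on an aromatic carbon gives a number no higher from compound 2 to compound 3 (the limit leaves the size open). The sizes of the steps in this series therefore cannot be read, because only limits stand on one or both sides: the limit of >= 20 ug/mL in this assay, at which 2 of the 3 values shown sit.

On these data alone, what an amine or a carboxylic acid at this position would do to the tolerated concentration stays open. So does the effect of replacing the remaining methoxy group with hydrogen.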